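Replacing a methoxy with a thiophene amide on the urea

This account rests on a few compounds, and the source may have more. Where it says the series, first, only, none or still open, it means among the compounds named here.

Compound 2 `COc1ccc(NC(=O)Nc2cccc(-c3nc(-c4ccc(NC(=O)c5cccnc5)cc4Cl)no3)c2)cc1C(F)(F)F` holds the lowest of the two numbers in a functional assay on MDA-MB-231 cells (Homo sapiens) for antiproliferative activity, read by MTT assay, with a stated time of 72 h; a higher number here means a weaker inhibitor, a lower number a stronger inhibitor; compound 1 `COc1cccc(NC(=O)Nc2cccc(-c3nc(-c4ccc(NC(=O)c5cccnc5)cc4Cl)no3)c2)c1` gives 6700 nM and compound 2 gives 1700 nM. Going by the values given here, the only measured step, a 3.9-fold lower number from compound 1 to compound 2 (0.60 log units; beyond the scatter), accounts for that gap.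

Compound 3 `O=C(Nc1cccc(-c2nc(-c3ccc(NC(=O)c4cccnc4)cc3Cl)no2)c1)Nc1ccc(NC(=O)c2cccs2)c(C(F)(F)F)c1` differs from compound 2 by ((thiophen-2-yl)carbonyl)amino in place of methoxy on an aromatic carbon. Among the compounds with values here, no measured step alters the same part of the molecule: the step from compound 1 to compound 2 exchanged 3-methoxyphenyl for 4-methoxy-3-(trifluoromethyl)phenyl, and the methoxy itself remained through that step. It shows only that this end of the urea accepts change with a modest gain, and it offers no direct guide to swapping the methoxy for the amide-bearing group. The estimate is therefore centred close to compound 2, with a wide range that leaves room for either a small gain or a loss, and the step expected is a 1.4-fold lower number from compound 2 to compound 3 (0.15 log units; within the scatter). Compound 3 is expected to give 1200 nM in this assay, with a range from 300 nM to 5000 nM.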

Compound 3, half-maximal inhibitory concentration: 2900 nM
Beside the measured number, compound 3's estimate is 2.4-fold (0.38 log units) below it; measured number inside the range.
By their numbers in this assay, from the lowest: compounds 2 and 3 (each within the scatter of the next); then compound 1.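

Going by these compounds alone, the step of a 1.7-fold higher number from compound 2 to compound 3 (0.23 log units; within the scatter) is the first measured change to the methoxy itself in this assay. It shows that this place on the ring, ortho to a trifluoromethyl group and para to a large group, accepts ((thiophen-2-yl)carbonyl)amino, with 8 heavy atoms, a five-membered aromatic ring and a hydrogen-bond donor, in place of a methoxy of 2 heavy atoms, and that the step stays within the scatter. No information bears on why so large an exchange leaves the read-out within the scatter.

The compounds shown leave open which part of the new group matters here, the amide link or the thiophene ring; a plain amine, an acetamide or a benzamide at this place would begin to separate the two. They also leave open whether this tolerance depends on the neighbouring substituent, which a compound carrying the same thiophene amide with a chlorine or a hydrogen in place of the trifluoromethyl group would test.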